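The source may report more compounds than this note shows. Statements on the series, on what has been measured and on what is new or still open speak of the compounds shown alone.

Of the compounds shown here, two have numbers so far. Compound 1 `COc1ccc(-c2ccc(-c3ccc(C(=N)N)o3)o2)cc1` gives 1470 nM in a functional assay on M14 cells (Homo sapiens) for inhibition, read by sulforhodamine B assay, with a stated time of 48 h; a higher number here means a weaker inhibitor of growth, a lower number a stronger inhibitor of growth; compound 2 `N=C(N)c1ccc(-c2ccc(-c3cncc4ccccc34)s2)s1` gives 1620 nM in this assay, and the two values sit within the scatter of each other, so neither stands apart. Compound 3 `N=C(N)c1ccc(-c2ccc(-c3ccccc3)o2)o1` is not yet measured; it differs from compound 1 by hydrogen in place of methoxy on an aromatic carbon. For the measured compounds named here, no measured pair shows this change, so the size of the step in this assay is unknown; a shift no larger than the scatter is expected, with no clear direction. For compound 3 the expected step is a 1.4-fold higher number from compound 1 to compound 3 (0.13 log units; within the scatter). Compound 3 is estimated at 2000 nM, within 900 nM to 4500 nM.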

Compound 3, concentration for 50% growth inhibition: 1620 nM
Compound 3: middle estimate off by 1.2-fold (0.09 log units), on the high side, and the stated range covers the measured number.
By their numbers in this assay, from the lowest: compounds 1, 2 and 3 (each within the scatter of the next).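

Hydrogen in place of methoxy on an aromatic carbon, para to a large group, gives a 1.1-fold higher number from compound 1 to compound 3 (0.04 log units; within the scatter) in this assay. For the compounds shown here, this is the first reading of this change, and it shows that growth inhibition on the core of compound 1 holds without the methoxy group at this position. No measurement available here offers a reason for this result.

On these data alone, whether an amine, a carboxylic acid or a longer alkoxy chain at this position would move the number remains open. A single pair also leaves open whether the same change behaves alike on other cores.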